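Notes on a bromo step from compound 1

The source may hold more compounds than are shown below. What is called first, only, known or untested is meant among the compounds shown, and "the series" means these compounds.

Compound 1 `Fc1ccc(-c2cn3nc(Cc4ccc(Cl)cc4)sc3n2)cc1` gives in a functional assay on L1210 cells (Mus musculus) for cytotoxicity, with a stated time of 48 h (on this read-out higher numbers stand for weaker inhibition and lower numbers for stronger inhibition), the value > 250000 nM, which is a limit of the assay and not a number.
Compound 2 `Clc1ccc(Cc2nn3cc(-c4ccc(Br)cc4)nc3s2)cc1` gives in this assay the value > 250000 nM, again a limit of the assay.
Compound 3 `Clc1ccc(Cc2nn3cc(-c4ccc(Cl)cc4Cl)nc3s2)cc1` gives in this assay the value 247000 nM.

Compound 1 stands at the limit; the limit of > 250000 nM in this assay, at which 2 of the 3 values shown sit, covers it together with compound 2. All measured steps change the aryl group on the shared core: a step that the two limits leave unreadable from compound 1 to compound 2 cannot be read, while an at least 1.0-fold lower number from compound 1 to compound 3 (0.00 log units; that floor lies within the scatter) and an at least 1.0-fold lower number from compound 2 to compound 3 (0.00 log units; that floor lies within the scatter) are floors lying within the scatter. None of them moves a number clearly away from the limit.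

Compound 4 `Fc1ccc(-c2nc3sc(Cc4ccc(Cl)cc4)nn3c2Br)cc1` differs from compound 1 in one place: bromo in place of hydrogen on an aromatic carbon. Going by the values given here, no measured step touches this position, so none of the three compounds bears directly on it; the steps to compound 3 only show that an aryl change leaves the series at or near the limit. For compound 4 in this assay no step beyond the scatter is expected, a number no higher from compound 1 to compound 4 (the limit leaves the size open). Compound 4 is expected at 250000 nM (range 100000 nM to 600000 nM), most likely reported again as a limit.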

Compound 4, half-maximal inhibitory concentration: > 250000 nM
Compound 4 was reported as a limit; the forecaster's own chance of this, stated with the estimate: 70%; the middle value lies on the limit itself.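

In this assay compound 4, like compound 1, gives a limit of the assay and not a number, so the step from compound 1 to compound 4 cannot be read: the limit of > 250000 nM in this assay, at which 3 of the 4 values shown sit.

The compounds shown leave open whether bromo in place of hydrogen at this position changes the read-out at all.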